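Extending the Chain on a Shared Core

The compounds below may be only part of what the source reports. "The series", "measured", "known", "first", "only" and "open" are said of these compounds alone.

Compound 1 `CCCCCCCCCCCCCCC1(C(N)=O)CO1`: 10 mg/kg
Compound 2 `CCCCCCC1(C(=O)OC)CO1`: 10 mg/kg

In a functional assay on the whole organism with Rattus norvegicus as the target, in the glucose tolerance test (a lower number here means that less compound is needed, a higher number that more compound is needed for the effect), compound 1 gives 10 mg/kg. Compound 2 gives 10 mg/kg in this assay, level with compound 1 within the scatter, although its chain is much shorter. Compound 3 `CCCCCCCCCCC1(C(=O)OC)CO1` has not yet been measured; it differs from compound 2 by butyl in place of hydrogen on a saturated chain carbon, six bonds along the chain from a saturated ring carbon. Because compound 1 at 10 mg/kg and compound 2 at 10 mg/kg sit level despite their different chain lengths, the step expected from this change is no change at the digits printed from compound 2 to compound 3 (within the scatter), none beyond the scatter. Compound 3 is therefore estimated at 10 mg/kg, with a range from 5 mg/kg to 20 mg/kg.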

Compound 3, minimum effective dose: 10 mg/kg
Compound 3: the middle estimate sits on the measured number at the digits printed; low and high end bracket the measured number.
By their numbers in this assay, from the lowest: compounds 1, 2 and 3 (each within the scatter of the next).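

Going by these compounds alone, this is the first comparison of two compounds that differ in only one place. Butyl in place of hydrogen on a saturated chain carbon, six bonds along the chain from a saturated ring carbon, gives no change at the digits printed from compound 2 to compound 3 (within the scatter) in this assay. At this position, then, the chain can be extended from methyl to pentyl without a visible effect on the minimum effective dose. Nothing available explains this flat result. Still open, on these data alone, is whether a longer chain, or an amine at the end of the chain, would shift the dose.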